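Sulfonyl swap on the compound 3 scaffold: pyridinyl to cyclopropyl

The compounds below may be only part of what the source reports. "The series", "measured", "known", "first", "only" and "open" are said of these compounds alone.

In a physicochemical assay for lipophilicity, measured as octanol-water partition, at pH 7.4 (a lower number here means a more polar compound, a higher number a more lipophilic compound), compound 1 (`Cc1ccc2[nH]c(C(=O)N[C@H]3CN(S(=O)(=O)c4ccnc(C)c4)C[C@@H]3C(=O)NCCN(C)C)cc2c1`) gives 1.7 and compound 2 (`Cc1ccc2[nH]c(C(=O)N[C@H]3CN(S(=O)(=O)C4CCOCC4)C[C@@H]3C(=O)NCCN(C)C)cc2c1`) gives 1. Compound 3 (`Cc1ccc2[nH]c(C(=O)N[C@H]3CCN(S(=O)(=O)c4cccnc4)C[C@@H]3C(=O)NCCN(C)C)cc2c1`) gives 1.3. That value lies within the scatter of compound 2 and beyond the scatter below compound 1.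

Compound 4 (`Cc1ccc2[nH]c(C(=O)N[C@H]3CCN(S(=O)(=O)C4CC4)C[C@@H]3C(=O)NCCN(C)C)cc2c1`) differs from compound 3 by cyclopropyl in place of pyridin-3-yl on a sulfonyl sulfur.

Among the measured compounds shown here, one measured step bears on this change: a number 0.70 log units lower from compound 1 to compound 2 (beyond the scatter), with oxan-4-yl in place of 2-methylpyridin-4-yl on a sulfonyl sulfur. The parallel is only partial. In both cases an aromatic ring leaves the sulfur and a non-aromatic ring enters, but the groups are different, and the core of compound 3 is not the core of compound 1. A change in the same direction is therefore expected in this assay, though smaller and probably not beyond the scatter. The expected step is a number 0.20 log units lower from compound 3 to compound 4 (within the scatter). The estimated value for compound 4 is 1.1, with an expected range of 0.7 to 1.5.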

Compound 4, distribution coefficient: 1
Estimate against measurement, compound 4: 0.10 log units above; the measured number falls inside the stated range.
By their numbers in this assay, from the lowest: compounds 2, 4 and 3 (each within the scatter of the next); then compound 1.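

On the core of compound 3, cyclopropyl in place of pyridin-3-yl on the sulfonyl sulfur gives a number 0.30 log units lower from compound 3 to compound 4 (within the scatter) in this assay: an aromatic ring with its hetero atom and hydrogen-bond acceptor leaves without a step beyond the scatter. Among the compounds shown here, the only earlier sulfonyl step, a number 0.70 log units lower from compound 1 to compound 2 (beyond the scatter), is printed as beyond the scatter, but it involves a different core and different groups, so the two steps do not establish one size for exchanging an aromatic ring for a non-aromatic ring on this sulfur. No measurement at hand gives a cause for the step from pyridin-3-yl to cyclopropyl.

As far as these compounds go, whether cyclopropyl gives a comparable step on the core of compound 1 remains open. Also open, from the compounds shown here alone, is how a longer chain such as n-butyl, or a ring carrying an amine or a carboxylic acid, would read on the sulfonyl sulfur in this assay.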